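The source may hold more compounds than are shown below. What is called first, only, known or untested is meant among the compounds shown, and "the series" means these compounds.

Two compounds share one core and differ only in the aryl group that sits on an amide-type nitrogen. Compound 1 `CCOc1ccc(NC(=O)Nc2cccc(CNc3nccnc3Cl)c2)cc1` carries a 4-ethoxyphenyl there, and in a functional assay on T-24 cells (Homo sapiens) for antiproliferative activity, read by MTT assay, with a stated time of 48 h (on this read-out higher numbers stand for weaker inhibition and lower numbers for stronger inhibition), compound 1 gives 9080 nM. Compound 2 `O=C(Nc1cccc(CNc2nccnc2Cl)c1)Nc1ccccc1F` carries a 2-fluorophenyl instead, and in this assay compound 2 gives 7450 nM. That is the lower of the two numbers, but the step of a 1.2-fold lower number from compound 1 to compound 2 (0.09 log units; within the scatter) lies within the scatter, so the two compounds cannot be told apart on this evidence.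

Compound 3 `O=C(Nc1cccc(CNc2nccnc2Cl)c1)Nc1ccc(Cl)cc1Br` is the next change at the same place: 2-bromo-4-chlorophenyl in place of 2-fluorophenyl on an amide-type nitrogen. Within the data shown here, the only measured step that bears on it is the exchange of one aryl group for another on this nitrogen, namely a 1.2-fold lower number from compound 1 to compound 2 (0.09 log units; within the scatter), which was small. Among the measured compounds shown here, nothing in the numbers so far shows that swapping aryl groups here moves the read-out beyond the scatter, so a similarly small step is expected in this assay, with no clear direction.

Compound 3 is therefore estimated at 6500 nM, within a range of 2500 nM to 17000 nM, which means an expected step of a 1.1-fold lower number from compound 2 to compound 3 (0.06 log units; within the scatter).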

Compound 3, half-maximal inhibitory concentration: 6650 nM
Compound 3: the middle estimate sits 1.0-fold (0.01 log units) below what was measured; the measured number falls inside the stated range.
By their numbers in this assay, from the lowest: compounds 3, 2 and 1 (each within the scatter of the next).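

In this assay, among these compounds, a third aryl group on this amide-type nitrogen still produces no step that stands clear of the usual scatter: the new change gives a 1.1-fold lower number from compound 2 to compound 3 (0.05 log units; within the scatter) and the pair with the most different numbers gives a 1.4-fold lower number from compound 1 to compound 3 (0.14 log units; within the scatter) and so also stays inside it. Here a single fluorine gives way to a chlorine and a bromine on the phenyl ring, with one more heavy atom in the group, and the read-out still cannot separate the compounds, so 4-ethoxyphenyl, 2-fluorophenyl and 2-bromo-4-chlorophenyl count as equivalent at this place on the present numbers. Nothing measured here offers an explanation for this flat result.

From the compounds shown here alone, all three compounds carry a substituted phenyl on this nitrogen, so it remains open whether a group of another kind there, such as a longer alkyl chain, an amine or a carboxylic acid, would move the number beyond the scatter. Going by these compounds, it also remains open whether changes elsewhere in the shared core would matter more than changes at this place.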